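Removing the Chloro Group from the Core of Compound 3

This account rests on a few compounds, and the source may have more. Where it says the series, first, only, none or still open, it means among the compounds named here.

Compound 3 `C#CCn1cc(C(=O)NC(CC(=O)Nc2ccccc2)c2ccccc2)c(=O)c2ccc(Cl)nc21` stands lowest among the numbers shown in a functional assay on MIA PaCa-2 cells (Homo sapiens) for cytotoxicity, read by MTT assay, with a stated time of 72 h (on this read-out lower numbers stand for stronger inhibition and higher numbers for weaker inhibition), where compound 3 gives 3000 nM. Going by the values given here, its nearest neighbour is compound 1 `C#CCn1cc(C(=O)NC(CC(=O)Nc2ccccc2)c2ccccc2)c(=O)c2cc(F)c(Cl)nc21`, which in this assay gives 6900 nM, and the step of a 2.3-fold lower number from compound 1 to compound 3 (0.36 log units; beyond the scatter) is the only measured change on the fused core. Compound 2 `C#CCn1cc(C(=O)NC(CC(=O)Nc2ccccn2)c2ccccc2)c(=O)c2ccc(Cl)nc21` reaches only the limit of this assay, > 10000 nM, so no number is known for it; the step of an at least 3.3-fold lower number from compound 2 to compound 3 (0.52 log units; beyond the scatter) concerns the amide-type nitrogen rather than the core.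

Compound 4 `C#CCn1cc(C(=O)NC(CC(=O)Nc2ccccc2)c2ccccc2)c(=O)c2cccnc21` differs from compound 3 by hydrogen in place of chloro on an aromatic carbon. Among the compounds with values here, of the measured steps, only the one from compound 1 to compound 3 concerns a halogen on the core, and there the loss of fluoro brought a modest gain; the change from compound 2 to compound 3 lies elsewhere. Within the data shown here, no measured step removes a chloro group, so the direction for this assay rests on weak footing. A modest shift, most likely toward a higher number, is expected, amounting to a 1.7-fold higher number from compound 3 to compound 4 (0.22 log units; within the scatter). Compound 4 is therefore estimated at 5000 nM, with a range from 2000 nM to 12000 nM.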

Compound 4, half-maximal inhibitory concentration: > 10000 nM
Compound 4 ended at the assay's limit; the forecaster's own chance of this, stated with the estimate: 20%; middle value at least 2.0-fold (0.30 log units) from the limit.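

Going by these compounds alone, replacing chloro with hydrogen on the aromatic carbon next to the ring nitrogen gives the first measured step at this position in this assay, and the number rises: an at least 3.3-fold higher number from compound 3 to compound 4 (0.52 log units; beyond the scatter). The earlier halogen step on the core went the other way, with loss of fluoro giving a 2.3-fold lower number from compound 1 to compound 3 (0.36 log units; beyond the scatter), so among the compounds shown, removing a halogen from the core has no single direction, and the chloro group is the one whose loss goes with the higher number. Compound 4 gives > 10000 nM, which is a limit of the assay and not a number, so the step has a lower bound only and its full size cannot be read: the limit of > 10000 nM in this assay, at which 2 of the 4 values shown sit.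

What a methyl group, a methoxy group or an amine would give on this same carbon remains open, so the compounds shown cannot say whether chloro itself is needed there or whether any group other than hydrogen would serve. Also open, as far as these compounds go, is whether the fluoro step would keep its direction on a core carrying hydrogen instead of chloro.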